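Removing the aryl substituent in the aminoalkoxy biaryl series

The source may report more compounds than this note shows. Statements on the series, on what has been measured and on what is new or still open speak of the compounds shown alone.

Measured so far:
compound 1 `CC(=O)Nc1cc(-c2ccc(OC[C@@H](N)CC(C)C)c(C)c2)ccn1` — 0.4 nM
compound 2 `CC(C)C[C@H](N)COc1ccc(-c2ccnc(NCc3ccccc3)c2)cc1` — 127 nM
compound 3 `CC(=O)Nc1cc(-c2ccc(OC[C@@H](N)CC(C)C)c(OC(F)(F)F)c2)ccn1` — 0.5 nM

In an assay on isolated protein for inhibition of AP2-associated protein kinase 1 (Homo sapiens), with a stated time of 3 h, in the presence of a further agent that is not named here (a higher number here means a weaker inhibitor, a lower number a stronger inhibitor), compound 3 gives 0.5 nM, the second highest of the three numbers. Compound 1 sits nearest to it, within the scatter; compound 2, with a benzylamino group in place of the acetamide, lies far above both.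

Compound 4 `CC(=O)Nc1cc(-c2ccc(OC[C@@H](N)CC(C)C)cc2)ccn1` differs from compound 3 by hydrogen in place of trifluoromethoxy on an aromatic carbon. Among the measured compounds shown here, the only measured step at this position is a 1.3-fold higher number from compound 1 to compound 3 (0.10 log units; within the scatter), which left the number essentially unchanged. For the measured compounds named here, no measured pair covers removal of the group altogether, so the expected step is a 1.6-fold higher number from compound 3 to compound 4 (0.20 log units; within the scatter), nothing beyond the scatter. Compound 4 is therefore estimated at 0.8 nM, with a range from 0.3 nM to 2.5 nM.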

Compound 4, half-maximal inhibitory concentration: 4.6 nM
Compound 4: the middle estimate sits 5.8-fold (0.76 log units) below what was measured, outside the stated range (above it).
By their numbers in this assay, from the lowest: compounds 1 and 3 (each within the scatter of the next); then compound 4; then compound 2.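

Methyl and trifluoromethoxy were interchangeable here, with a 1.3-fold higher number from compound 1 to compound 3 (0.10 log units; within the scatter) in this assay, but hydrogen is not equivalent to either: the data show a 9.2-fold higher number from compound 3 to compound 4 (0.96 log units; beyond the scatter) and a 12-fold higher number from compound 1 to compound 4 (1.06 log units; beyond the scatter) on loss of the group ortho to the (2-amino-4-methylpentyl)oxy group. Without that group, the nitrogen substituent can be compared directly, giving a 28-fold lower number from compound 2 to compound 4 (1.44 log units; beyond the scatter) for acetyl in place of benzyl. No measurement here explains the loss on removal.

Open, on these data alone, is whether fluorine, chlorine or a nitrile at this position matches methyl. Also open, as far as these compounds go, is whether a longer acyl chain on the nitrogen retains the acetyl result.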